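This account rests on a few compounds, and the source may have more. Where it says the series, first, only, none or still open, it means among the compounds named here.

Measured compounds:
Compound 1 `CO/N=C(\CCN1CCN(c2ccccn2)CC1)c1ccccc1Cl` — 42.3 nM
Compound 2 `CO/N=C(\CCN1CCN(c2ccccn2)CC1)c1ccccc1C` — 74 nM

In a functional assay on HEK293 cells with D(4) dopamine receptor (Homo sapiens) as the target, read by FLIPR (on this read-out higher numbers stand for an effect only at larger amounts of compound and lower numbers for an effect already at smaller amounts), compound 2 gives 74 nM, the highest of the two numbers; its nearest neighbour is compound 1, and the step of a 1.7-fold higher number from compound 1 to compound 2 (0.24 log units; within the scatter) lies within the scatter, so the two compounds cannot be told apart on this read-out.

Compound 3 `CO/N=C(\CCN1CCN(c2ccccn2)CC1)c1ccc(Cl)cc1` has not yet been measured. It differs from compound 2 by 4-chlorophenyl in place of 2-methylphenyl on a carbon with a double bond to nitrogen. Among the measured compounds shown here, only the step from compound 1 to compound 2 bears on this change, and only in part: it swapped chloro for methyl at an unchanged place on the ring and was within the scatter, a 1.7-fold higher number from compound 1 to compound 2 (0.24 log units; within the scatter). For the measured compounds named here, no measured pair shows what moving the substituent to a different place on the ring does. Going by the values given here, since the only related step was within the scatter, compound 3 is expected to sit near compound 2, with a step of a 1.1-fold lower number from compound 2 to compound 3 (0.02 log units; within the scatter) that may fall either way. Compound 3 is therefore estimated at 70 nM, within a range of 15 nM to 350 nM.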

Compound 3, half-maximal effective concentration: 37.6 nM
Estimate against measurement, compound 3: 1.9-fold (0.27 log units) above; the range from low to high includes it.
By their numbers in this assay, from the lowest: compounds 3, 1 and 2 (each within the scatter of the next).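

Among the compounds shown here, compound 3 carries 4-chlorophenyl where compound 1 carries 2-chlorophenyl, and a 1.1-fold lower number from compound 1 to compound 3 (0.05 log units; within the scatter) is the first measured view of chlorine at a different place on the ring; in this assay that move cannot be told apart from no change. Replacing 2-methylphenyl with 4-chlorophenyl gives a 2.0-fold lower number from compound 2 to compound 3 (0.29 log units; within the scatter) and also stays within the scatter, so on the carbon with a double bond to nitrogen these two groups cannot be separated on this read-out, although the step is close to its edge.

On these data alone, whether an amine or a carboxylic acid on the ring, in place of the chloro or methyl, would move the number remains open. So does the effect of a longer chain in the shared core. Nothing measured beyond these numbers accounts for how closely the three compounds agree.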